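Methylamino in place of phenylethylamino: cytotoxicity notes

This account rests on a few compounds, and the source may have more. Where it says the series, first, only, none or still open, it means among the compounds named here.

Measured compounds:
compound 1 `O=C(NCc1ccc(F)cc1)c1nc(NCCO)c2cccnc2c1O` — > 20000 nM
compound 2 `C[C@@H](Nc1c(C(=O)NCc2ccc(F)cc2)nc(Br)c2cccnc12)c1ccccc1` — > 20000 nM
compound 3 `COC(=O)c1nc(Br)c2cccnc2c1N[C@H]1CC[C@H](N)CC1` — > 20000 nM

In a functional assay on MDA-MB-435 cells (Homo sapiens) for cytotoxicity, read by MTT assay, with a stated time of 72 h (on this read-out lower numbers stand for stronger inhibition and higher numbers for weaker inhibition), compound 1 gives > 20000 nM, which is a limit of the assay rather than a number. Compound 2 likewise gives > 20000 nM, a limit. Compound 3 gives > 20000 nM, also a limit. For the measured compounds named here, compound 2 thus stands with the other two at the limit of > 20000 nM in this assay, at which 3 of the 3 values shown sit; no order among the three can be drawn, and no measured step exists.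

Compound 4 `CNc1c(C(=O)NCc2ccc(F)cc2)nc(Br)c2cccnc12` differs from compound 2 by methyl in place of 1-phenylethyl on a nitrogen on an aromatic ring. With every measured value sitting at the limit, the expected step is a step that the limit leaves unreadable from compound 2 to compound 4, that is, none beyond the scatter. Compound 4 is expected at 30000 nM, within 15000 nM to 80000 nM, and most probably reported again only as a limit.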

Compound 4, half-maximal inhibitory concentration: > 20000 nM
Compound 4: only a limit was reported (the forecaster's own chance of this, stated with the estimate: 85%); the middle value does not contradict the limit.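

No step can be read from compound 2 to compound 4, as both values are limits: the limit of > 20000 nM in this assay, at which 4 of the 4 values shown sit.

The compounds shown leave open which change to the shared core, if any, would give a number rather than a limit.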